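Swapping the outer ring group of compound 3

The source may hold more compounds than are shown below. What is called first, only, known or untested is meant among the compounds shown, and "the series" means these compounds.

Measured so far in a functional assay on HCT-116 cells (Homo sapiens) for inhibition; on this read-out lower numbers stand for stronger inhibition and higher numbers for weaker inhibition:
- compound 1 `CCNC(=O)c1noc(-c2cc(C(C)C)c(O)cc2O)c1-c1cc(CNC(C)=O)no1` gives 167 nM
- compound 2 `CCNC(=O)c1noc(-c2cc(C(C)C)c(O)cc2O)c1-c1cc(C(=O)NC)no1` gives 124 nM
- compound 3 `CCNC(=O)c1cc(-c2c(C(=O)NCC)noc2-c2cc(C(C)C)c(O)cc2O)on1` gives 14 nM

Compound 3 stands lowest of the three. The steps reaching it are a 12-fold lower number from compound 1 to compound 3 (1.08 log units; beyond the scatter) and an 8.9-fold lower number from compound 2 to compound 3 (0.95 log units; beyond the scatter), whereas a 1.3-fold lower number from compound 1 to compound 2 (0.13 log units; within the scatter) stays small. Compound 4 `CCNC(=O)c1noc(-c2cc(C(C)C)c(O)cc2O)c1-c1ccn(C(C)C)n1` brings 1-isopropyl-1H-pyrazol-3-yl in place of 3-(ethylcarbamoyl)-1,2-oxazol-5-yl on an aromatic carbon. For the measured compounds named here, no measured step makes this exchange. Compound 4 loses the ethylcarbamoyl group, whose arrival gave an 8.9-fold lower number from compound 2 to compound 3 (0.95 log units; beyond the scatter) in the closest measured case, so a loss of similar size is the working guide. A move to a higher number in this assay is expected: a 6.4-fold higher number from compound 3 to compound 4 (0.81 log units; beyond the scatter). For compound 4 the estimated value is 90 nM within an expected range of 25 nM to 350 nM.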

Compound 4, half-maximal inhibitory concentration: 19 nM
Compound 4: middle estimate off by 4.7-fold (0.68 log units), on the high side, and the stated range ends above it.
By their numbers in this assay, from the lowest: compounds 3 and 4 (each within the scatter of the next); then compounds 2 and 1 (each within the scatter of the next).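

In this assay the ethylcarbamoyl group proves not to be needed at this position: 1-isopropyl-1H-pyrazol-3-yl, with 0 hydrogen-bond donors, holds level with 3-(ethylcarbamoyl)-1,2-oxazol-5-yl, a 1.4-fold higher number from compound 3 to compound 4 (0.13 log units; within the scatter). The same ring also gives a 6.5-fold lower number from compound 2 to compound 4 (0.81 log units; beyond the scatter) and an 8.8-fold lower number from compound 1 to compound 4 (0.94 log units; beyond the scatter), so a low number here does not depend on the ethylcarbamoyl-bearing ring. No data shown explain this result. From the compounds shown here alone, how far compound 4 depends on its isopropyl group remains open; methyl or a longer chain such as butyl on the pyrazole nitrogen would address this.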